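Moving From Compound 3 to Compound 4 in Paw Edema Inhibition

A few compounds are considered here, and "the series" means these few. Any claim that something is new, unique, unknown or untested is made for them only; others in the source may bear on it.

Three compounds share one core. Compound 1 `CC1=C(C(=O)Nc2ccc(F)cc2)C(c2ccc([N+](=O)[O-])cc2)n2c(s/c(=C/c3ccccc3Cl)c2=O)=N1` gives 19% in a functional assay on the whole organism (strain albino) for inhibition, with Rattus norvegicus as the target, read by paw edema, with stated times of 1 h and 3 h, at a dose of 25 mg/kg by the oral route; a higher number here means more inhibition at the dose given (going by the name of the read-out), a lower number less inhibition. Compound 2 `CC1=C(C(=O)Nc2ccc(F)cc2)C(c2ccc(Cl)cc2)n2c(s/c(=C/c3ccc(Br)cc3)c2=O)=N1` gives 35% in this assay. Compound 3 `CC1=C(C(=O)Nc2ccc(F)cc2)C(c2ccc(Cl)cc2)n2c(s/c(=C/c3ccc(F)cc3)c2=O)=N1` gives 44% in this assay, the highest number of the three, although compound 2 lies within the scatter of it and only compound 1 lies beyond. Among the measured compounds shown here, the single measured step, a number 9 percentage points higher from compound 2 to compound 3 (within the scatter), is within the scatter. Compound 4 `CC1=C(C(=O)Nc2ccc(F)cc2)C(c2ccc(Cl)cc2)n2c(s/c(=C/c3ccccc3Cl)c2=O)=N1` differs from compound 3 in one place: 2-chlorophenyl in place of 4-fluorophenyl on a double-bonded chain carbon bound to an aromatic carbon. For the measured compounds named here, compound 1 also carries a 2-chlorophenyl there, yet it differs from compound 4 elsewhere too, so no measured step bears directly on this change. Compound 4 is nonetheless expected to come out lower, an expected step of a number 14 percentage points lower from compound 3 to compound 4 (beyond the scatter). Compound 4 is estimated at 30%, with a range from 15% to 45%.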

Compound 4, a percentage reported as inhibition, in the whole organism at one dose (the size of the read-out at that dose, not a potency): 16%
The estimate for compound 4 lay 14 percentage points above the measured number; low and high end bracket the measured number.
By their numbers in this assay, from the lowest: compounds 4 and 1 (each within the scatter of the next); then compounds 2 and 3 (each within the scatter of the next).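

Placing 2-chlorophenyl on the double-bonded chain carbon gives a number 28 percentage points lower from compound 3 to compound 4 (beyond the scatter) and a number 19 percentage points lower from compound 2 to compound 4 (beyond the scatter) when it replaces 4-bromophenyl, so this position responds to the change of aryl group, which no earlier step showed. With 2-chlorophenyl in place, chloro in place of nitro on an aromatic carbon gives only a number 3 percentage points lower from compound 1 to compound 4 (within the scatter) and does not separate the two compounds. Nothing available explains the loss of inhibition at this position.

The compounds shown leave open whether the loss goes with the chlorine or with its place on the ring, a question that 4-chlorophenyl or 2-fluorophenyl here would address. Going by these compounds, how an amine or a carboxylic acid on this ring would read also stays open.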